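Terminal vinyl on the long chain of compound 2

The source may report more compounds than this note shows. Statements on the series, on what has been measured and on what is new or still open speak of the compounds shown alone.

Going by the values given here, compound 2 `CCCCCCCCCC(=O)c1nc2ncccc2o1` gives 74.1 nM in an assay on HEK-293T cells for inhibition of diacylglycerol lipase-alpha (Homo sapiens), read by colorimetric assay (on this read-out lower numbers stand for stronger inhibition and higher numbers for weaker inhibition), and stands lowest of the two numbers measured so far. Its nearest neighbour is compound 1 `O=C(CCCCc1ccccc1)c1nc2ncccc2o1`, which in this assay gives 204 nM. Among the compounds with values here, the one step recorded is a 2.8-fold lower number from compound 1 to compound 2 (0.44 log units; beyond the scatter); it exchanged an aromatic group for a saturated chain on a saturated chain carbon four bonds along the chain from the carbonyl carbon and counts as modest.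

Compound 3 `C=CCCCCCCCC(=O)c1nc2ncccc2o1` differs from compound 2 by vinyl in place of ethyl on a saturated chain carbon, seven bonds along the chain from a carbonyl carbon. Within the data shown here, no measured step touches a double bond within the chain, and the only step at hand, a 2.8-fold lower number from compound 1 to compound 2 (0.44 log units; beyond the scatter), changes a different part of the molecule, so it bears on the new compound only loosely, as a sign that the far part of the chain tolerates change. In this assay the expectation is therefore a small step at most, in no firm direction, likely within the scatter. Compound 3 is estimated at 80 nM, with a range of 40 nM to 160 nM. This expectation means a 1.1-fold higher number from compound 2 to compound 3 (0.03 log units; within the scatter).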

Compound 3, half-maximal inhibitory concentration: 550 nM
For compound 3 the middle estimate is 6.9-fold (0.84 log units) below the measured one, and the stated range ends below it.
By their numbers in this assay, from the lowest: compound 2; then compound 1; then compound 3.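

Seven bonds along the chain from a carbonyl carbon, this place does respond to a small change: vinyl in place of ethyl gives a 7.4-fold higher number from compound 2 to compound 3 (0.87 log units; beyond the scatter) in this assay, although the same count of heavy atoms leaves and enters and the counted difference is 1 double bond outside aromatic rings. Compared with phenyl, the saturated and unsaturated chains also part in direction, since pentyl gives a 2.8-fold lower number from compound 1 to compound 2 (0.44 log units; beyond the scatter), whereas pent-4-en-1-yl gives a 2.7-fold higher number from compound 1 to compound 3 (0.43 log units; beyond the scatter), so a chain of this kind is not enough on its own to give the lower number seen with compound 2. No measurement at hand accounts for the rise in compound 3.

The compounds shown leave open whether the rise follows this double bond at this place or would also come with a double bond elsewhere along the chain, or with an alkyne in its place. They also leave open how a longer chain, a shorter chain or a hydroxyl group at this place would read, and whether the rise would carry over to other chains on the shared core.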